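Compound 4 Estimated from Three Weakly Active Analogues

This account rests on a few compounds, and the source may have more. Where it says the series, first, only, none or still open, it means among the compounds named here.

Three compounds have been measured in a functional assay on HCT-116 cells (Homo sapiens) for antiproliferative activity, read by MTT assay, with a stated time of 48 h; a lower number here means a stronger inhibitor, a higher number a weaker inhibitor:

compound 1 `Cc1cccc(-n2nncc2CN2C(=O)C3(C(C#N)=C(N)Oc4c3c3nc5ccccc5nc3c3ccccc43)c3ccccc32)c1`: > 50000 nM
compound 2 `N#CC1=C(N)Oc2c(c3nc4ccccc4nc3c3ccccc23)C12C(=O)N(Cc1cnnn1-c1ccc([N+](=O)[O-])cc1)c1ccccc12`: > 50000 nM
compound 3 `N#CC1=C(N)Oc2c(N)cc3nc4ccccc4nc3c2C12C(=O)N(Cc1cnnn1-c1cccc(Br)c1)c1ccccc12`: 26100 nM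

The value of compound 1 is a limit of this assay rather than a number. The value of compound 2 is likewise a limit. Compound 3 is the only one of the three that gives a number, and so it stands alone among the values shown. Among the measured compounds shown here, the single step between measured compounds that differ in one place, a step that the two limits leave unreadable from compound 1 to compound 2, runs between two limits and has no readable size.

Compound 4 `COc1ccc(OC)c(-n2nncc2CN2C(=O)C3(C(C#N)=C(N)Oc4c(N)cc5nc6ccccc6nc5c43)c3ccccc32)c1` differs from compound 3 in one place: 2,5-dimethoxyphenyl in place of 3-bromophenyl on an aromatic nitrogen. For the measured compounds named here, no measured step concerns this position with this pair of groups, and the limit of > 50000 nM in this assay, at which 2 of the 3 values shown sit, is the only evidence on the measured steps; it says nothing about the change from compound 3 to compound 4. The step of a 1.1-fold higher number from compound 3 to compound 4 (0.06 log units; within the scatter) is therefore expected to lie within the scatter. In this assay compound 4 is estimated at 30000 nM, in a range from 10000 nM to 100000 nM, with a real chance that only a limit is reported.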

Compound 4, half-maximal inhibitory concentration: > 50000 nM
Compound 4: no number, only a limit; the forecaster's own chance of this, stated with the estimate: 45%; at least 1.6-fold (0.22 log units) between middle value and limit.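

In this assay, among the compounds shown here, the change from 3-bromophenyl to 2,5-dimethoxyphenyl on the aromatic nitrogen gives an at least 1.9-fold higher number from compound 3 to compound 4 (0.28 log units; that floor lies within the scatter) and is the first step at this position with a readable size, since the earlier step ran between two limits and cannot be read. Compound 4 gives only a limit, so this step is a floor, and that floor alone does not place the change beyond the scatter. Compound 3 remains the only compound with a number, and the limit is now the most common result in the set: the limit of > 50000 nM in this assay, at which 3 of the 4 values shown sit.

On these data alone, how far compound 4 lies past its limit remains open, and with it the full size of the step. Also open, as far as these compounds go, is what an amine or a carboxylic acid on this phenyl ring, in place of the bromine or the methoxy groups, would give in this assay on this core.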